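Removing a Methyl Where Every Neighbour Sits at the Limit

The source may hold more compounds than are shown below. What is called first, only, known or untested is meant among the compounds shown, and "the series" means these compounds.

Compound 1, `Cc1ccc2nc(Nc3nc(Nc4ccc(S(N)(=O)=O)cc4)ncc3C)sc2c1`: > 50000 nM
Compound 2, `Cc1cnc(Nc2ccc(S(N)(=O)=O)cc2)nc1Nc1nc2ccccc2s1`: > 50000 nM
Compound 3, `COc1ccc2nc(Nc3nc(Nc4ccc(S(N)(=O)=O)cc4)ncc3C)sc2c1`: > 50000 nM

In a functional assay on MCF7 cells (Homo sapiens) for antiproliferative activity, read by MTT assay, with a stated time of 48 h (a lower number here means a stronger inhibitor, a higher number a weaker inhibitor), compound 3 gives only a limit, > 50000 nM, not a number. The same is true of compound 1, whose value > 50000 nM is a limit. Compound 2 likewise stops at the limit > 50000 nM. Thus the limit of > 50000 nM in this assay, at which 3 of the 3 values shown sit, describes every measured compound here, and compound 3 can be placed no more precisely than at that limit alongside the other two.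

Compound 4, `COc1ccc2nc(Nc3ccnc(Nc4ccc(S(N)(=O)=O)cc4)n3)sc2c1`, differs from compound 3 by hydrogen in place of methyl on an aromatic carbon. The closest measured step of the same kind, a methyl exchanged for hydrogen on an aromatic carbon, is a step that the two limits leave unreadable from compound 1 to compound 2; the steps a step that the two limits leave unreadable from compound 1 to compound 3 and a step that the two limits leave unreadable from compound 2 to compound 3 are equally unreadable, since both ends sit at the limit. For the measured compounds named here, none of the measured steps therefore gives a size or direction for this change in this assay.

With all three neighbours at the limit, compound 4 is expected to return a limit as well, so the step of a number no higher from compound 3 to compound 4 (the limit leaves the size open) is estimated as essentially none. The value of compound 4 is estimated at 50000 nM, within 20000 nM to 120000 nM, most likely reported as a limit.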

Compound 4, half-maximal inhibitory concentration: 11000 nM
The estimate for compound 4 lay 4.5-fold (0.66 log units) above the measured number; measured number below the stated range.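

Hydrogen in place of methyl on this aromatic carbon, ortho to a large group and two atoms from the ring nitrogen, gives in this assay an at least 4.5-fold lower number from compound 3 to compound 4 (0.65 log units; beyond the scatter). For the compounds shown here, this is the first readable direction for this change, since the steps among compounds 1, 2 and 3 cannot be read, and the size printed here is only a floor, as compound 3 has a limit and not a number. Compound 4 is the only compound shown that gives a number rather than a limit, so the methyl position is the one change shown to move a compound off the shared limit, at least with the methoxy group in place: the limit of > 50000 nM in this assay, at which 3 of the 4 values shown sit.

The compounds shown leave open whether the same exchange would bring the analogues of compound 1 or compound 2 off the limit, or whether it holds only with the methoxy group of compound 3 and compound 4 on the other side of the molecule. They also leave open what a longer chain such as ethyl, an amine or a chlorine atom would do on this aromatic carbon, and how far below the limit any such compound would fall.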